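Adding a Methyl to a Hydroxy Group on Two Related Cores

This account rests on a few compounds, and the source may have more. Where it says the series, first, only, none or still open, it means among the compounds named here.

Compound 1 `O=C(Nc1cccc(-n2cc(-c3ccncc3)c(-c3cc(O)cc(Cl)c3)n2)c1)Nc1ccc(Cl)c(C(F)(F)F)c1` carries a hydroxy group on one of its aromatic rings. In a functional assay on SNB-75 cells (Homo sapiens) for inhibition, read by sulforhodamine B assay, with a stated time of 48 h, tested at 10 uM (on this read-out lower numbers stand for a stronger effect and higher numbers for a weaker effect at the one concentration tested), compound 1 gives 24.1%. Compound 2 `COc1cc(Cl)cc(-c2nn(-c3cccc(NC(=O)Nc4ccc(Cl)c(C(F)(F)F)c4)c3)cc2-c2ccncc2)c1` differs from it in a single place, (methyl in place of hydrogen on an oxygen on an aromatic ring). In this assay compound 2 gives 14.5%. The resulting step, a number 9.6 percentage points lower from compound 1 to compound 2 (within the scatter), is small. Compound 3 `O=C(Nc1cccc(-n2cc(-c3ccncc3)c(-c3cc(O)cc(Cl)c3)n2)c1)c1cc(C(F)(F)F)cc(C(F)(F)F)c1` rests on a different core; how it differs from compound 1 is not broken down here. In this assay compound 3 gives 52.7%, the highest number of the three and so the weakest effect among them. Compound 4 `COc1cc(Cl)cc(-c2nn(-c3cccc(NC(=O)c4cc(C(F)(F)F)cc(C(F)(F)F)c4)c3)cc2-c2ccncc2)c1` has not yet been measured. It stands to compound 3 exactly as compound 2 stands to compound 1, with the same change at the same place: methyl in place of hydrogen on an oxygen on an aromatic ring. On the strength of the step of a number 9.6 percentage points lower from compound 1 to compound 2 (within the scatter), which stayed within the scatter, the expected step of a number 7.7 percentage points lower from compound 3 to compound 4 (within the scatter) is likewise small. Compound 4 is therefore estimated at 45% in this assay, with a likely range from 28% to 62%.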

Compound 4, a percentage reported as activity, at one concentration (the size of the read-out at that concentration, not a potency): 60.8%
Compound 4: the middle estimate sits 15.8 percentage points below what was measured; the range from low to high includes it.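

In this assay, exchanging hydroxy for methoxy on the core of compound 3 gives a number 8.1 percentage points higher from compound 3 to compound 4 (within the scatter), so this step alone shows no clear change in the read-out. Set beside the earlier step, however, the same change does not give the same result on the two cores: the same change on two cores in this assay, a number 9.6 percentage points lower (within the scatter) from compound 1 to compound 2 and a number 8.1 percentage points higher (within the scatter) from compound 3 to compound 4, 17.7 percentage points apart, beyond the scatter of two such steps. Going by these compounds alone, this shows that a step seen on one core cannot simply be added to a compound on the other core, but with only two pairs it does not show why the steps differ, nor how the change would behave on any further core.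

The compounds shown leave open how an amine in place of the hydroxy group, or an ethyl group in place of the methyl on the same oxygen, would read in this assay. They also leave open whether the gap between the two steps would hold at other concentrations, since each number comes from a single concentration and is not a potency.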